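The source may report more compounds than this note shows. Statements on the series, on what has been measured and on what is new or still open speak of the compounds shown alone.

Three compounds sharing one core have been examined in a functional assay on A549 cells (Homo sapiens), read by MTT assay, with a stated time of 72 h; on this read-out higher numbers stand for weaker inhibition and lower numbers for stronger inhibition. Compound 1 `COc1ncnc2c1c(-c1ccsc1)cn2[C@@H]1O[C@H](CO)[C@@H](O)[C@H]1O` gives 5170 nM in this assay. Compound 3 `COc1ncnc2c1c(-c1cccs1)cn2[C@@H]1O[C@H](CO)[C@@H](O)[C@H]1O` gives 4850 nM in this assay. The two cores differ by thiophen-2-yl in place of thiophen-3-yl on an aromatic carbon, and the step of a 1.1-fold lower number from compound 1 to compound 3 (0.03 log units; within the scatter), so the two values show no difference worth reading.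

Compound 2 `COc1nc(N)nc2c1c(-c1ccsc1)cn2[C@@H]1O[C@H](CO)[C@@H](O)[C@H]1O` is reported in this assay only as a limit of the assay, > 100000 nM. Compound 2 differs from compound 1 by amino in place of hydrogen on an aromatic carbon, and the step of an at least 19-fold higher number from compound 1 to compound 2 (1.28 log units; beyond the scatter). This value sits at the limit of > 100000 nM in this assay, at which 1 of the 3 values shown sits.

Compound 4 `COc1nc(N)nc2c1c(-c1cccs1)cn2[C@@H]1O[C@H](CO)[C@@H](O)[C@H]1O` has not yet been measured in this assay. It differs from compound 3 by amino in place of hydrogen on an aromatic carbon, which is the same change as that from compound 1 to compound 2, at a place described in the same words. The step from compound 3 to compound 4 is therefore expected to be large, roughly a 21-fold higher number from compound 3 to compound 4 (1.31 log units; beyond the scatter), because the earlier step of an at least 19-fold higher number from compound 1 to compound 2 (1.28 log units; beyond the scatter). Compound 4 is expected to give about 100000 nM in this assay, most likely reported again only as a limit, within a range from 30000 nM to 300000 nM.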

Compound 4, half-maximal inhibitory concentration: > 20000 nM
Compound 4 ended at the assay's limit; the forecaster's own chance of this, stated with the estimate: 80%; the middle value lies beyond the limit too.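

In this assay the amino group in place of hydrogen again goes with a higher number, an at least 4.1-fold higher number from compound 3 to compound 4 (0.61 log units; beyond the scatter) and so the change points the same way on the thiophen-2-yl core as on the thiophen-3-yl core: the same change on two cores in this assay, an at least 19-fold higher number (1.28 log units; beyond the scatter) from compound 1 to compound 2 and an at least 4.1-fold higher number (0.61 log units; beyond the scatter) from compound 3 to compound 4; the limit leaves it open whether they differ.
For the compounds shown here, this shows that the direction carries over between these two cores, in the only two pairs available. It does not show that the size carries over, since compound 2 and compound 4 both stand only as limits of the assay, and the step between those two compounds cannot be read for the same reason.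

The compounds shown leave open whether any other group on this aromatic carbon, such as a methylamino group or a chlorine atom, would go with the same loss as amino. They also leave open how far the two amino compounds truly lie from their hydrogen partners, and whether a phenyl group in place of the thiophene would keep the direction.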